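1-Hydroxyethyl to 1-hydroxy-1-methylethyl: a step without a readable precedent

The source may report more compounds than this note shows. Statements on the series, on what has been measured and on what is new or still open speak of the compounds shown alone.

In a physicochemical assay for solubility, read by chemiluminescence, measured as kinetic solubility (a lower number here means a less soluble compound, a higher number a more soluble compound), compound 1 `CC(=O)NCc1cccc(Cn2nc(NS(=O)(=O)c3ccc(Cl)s3)c3ccccc32)c1` gives >= 117 ug/mL, which is a limit. Compound 2 `CC(=O)NCc1cccc(Cn2nc(NS(=O)(=O)c3ccc(Cl)s3)c3c(CO)cccc32)c1` gives >= 113 ug/mL, also a limit. Compound 3 `CC(=O)NCc1cccc(Cn2nc(NS(=O)(=O)c3ccc(Cl)s3)c3c(C(C)O)cccc32)c1` gives >= 208 ug/mL, again a limit and not a number.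

Compound 4 `CC(=O)NCc1cccc(Cn2nc(NS(=O)(=O)c3ccc(Cl)s3)c3c(C(C)(C)O)cccc32)c1` differs by methyl in place of hydrogen on a saturated chain carbon bound to an aromatic carbon, an oxygen on a saturated carbon and a saturated chain carbon. Within the data shown here, the nearest precedent, also a methyl in place of hydrogen on a saturated chain carbon, is a step that the two limits leave unreadable from compound 2 to compound 3. The other two steps are a step that the two limits leave unreadable from compound 1 to compound 2 and a step that the two limits leave unreadable from compound 1 to compound 3. None of the three gives a size or direction, so no step beyond the scatter is expected in this assay. The expected change is an at least 1.1-fold lower number from compound 3 to compound 4 (0.06 log units; that floor lies within the scatter). Compound 4 is estimated at 180 ug/mL, with an expected range of 100 ug/mL to 260 ug/mL.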

Compound 4, solubility: >= 159 ug/mL
Compound 4 was reported as a limit; the forecaster's own chance of this, stated with the estimate: 75%; the middle value is on the limit's open side.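

No new step can be read in this assay: compound 1, compound 2, compound 3 and compound 4 are all reported only as limits. The compounds shown leave open the size and direction of every step among them, including 1-hydroxyethyl to 1-hydroxy-1-methylethyl.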